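The source may report more compounds than this note shows. Statements on the series, on what has been measured and on what is new or still open speak of the compounds shown alone.

In a functional assay on SMMC-7721 cells (Homo sapiens) for cytotoxicity, read by MTT assay, with a stated time of 48 h (on this read-out higher numbers stand for weaker inhibition and lower numbers for stronger inhibition), compound 1 (`COc1cc(O)c2c(c1O)C/C(C)=C\[C@@H](O)C[C@@]1(C)O[C@@H]1C2=O`) gives 14900 nM. Its only measured relative, compound 2 (`COc1cc(O)c2c(c1O)C[C@]1(C)O[C@@H]1CC[C@@]1(C)O[C@@H]1C2=O`), gives 11300 nM, so the two lie within the usual scatter of each other and neither can be set apart. Compound 3 (`COc1cc(O)c2c(c1O)C/C(C)=C\CC[C@@]1(C)O[C@@H]1C2=O`) has not yet been measured in this assay. It departs from compound 1 by a single change, hydrogen in place of hydroxy on a saturated ring carbon. For the measured compounds named here, no measured pair shows this change, so the data offer no direct guide to its size or direction. The expectation therefore rests on compound 1 at 14900 nM, and no shift beyond the scatter is anticipated in either direction. The estimated step is a 1.1-fold lower number from compound 1 to compound 3 (0.06 log units; within the scatter). For compound 3 the expected value is 13000 nM, with an estimated range of 5500 nM to 30000 nM.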

Compound 3, half-maximal inhibitory concentration: 24700 nM
The estimate for compound 3 lay 1.9-fold (0.28 log units) below the measured number; the range from low to high includes it.
By their numbers in this assay, from the lowest: compounds 2, 1 and 3 (each within the scatter of the next, the first and the last beyond it).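

For the compounds shown here, the pair gives the first direct reading of this saturated ring carbon: in this assay, taking hydrogen in place of hydroxy gives a 1.7-fold higher number from compound 1 to compound 3 (0.22 log units; within the scatter). On this one pair, the hydroxy, with its hydrogen-bond donor and acceptor, can give way to hydrogen without a shift that stands clear of the scatter, so the pair gives no sign that the group matters for this read-out. Nothing available bears on the reason for this result.

The compounds shown leave open whether a different group on this carbon, such as an amine, a fluorine atom or a carboxylic acid, would move the number beyond the scatter. They also leave open whether the same change would read alike on other cell lines.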